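The source may report more compounds than this note shows. Statements on the series, on what has been measured and on what is new or still open speak of the compounds shown alone.

Working notes on the series, all read in an ADME assay on NCM460 cells (Homo sapiens) for cytotoxicity, read by CCK-8 assay, with a stated time of 48 h; on this read-out higher numbers stand for weaker inhibition and lower numbers for stronger inhibition:
- compound 1 `COc1ccc(/C=C\c2cc(OC)c(OC)c(OC)c2)cc1OCc1ccc(CN[C@H](C(=O)O)[C@H](C)O)cc1`: > 50000 nM (a limit)
- compound 2 `COc1ccc(/C=C\c2cc(OC)c(OC)c(OC)c2)cc1OCc1ccc(CN2CC[C@H](O)C2)cc1`: 51000 nM
- compound 3 `COc1ccc(/C=C\c2cc(OC)c(OC)c(OC)c2)cc1OCc1ccc(CNCCNC(C)=O)cc1`: 54000 nM
- compound 4 `COc1ccc(/C=C\c2cc(OC)c(OC)c(OC)c2)cc1OCc1ccc(CN2CC[C@@H](C(=O)O)C2)cc1`: not yet measured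

Compound 3 gives 54000 nM and stands level, within the scatter, with compound 2 at 51000 nM. Compound 1 gives > 50000 nM, which is a limit and not a number.

The change to compound 4 is 3-carboxypyrrolidin-1-yl in place of (2-acetamidoethyl)amino on a saturated chain carbon bound to an aromatic carbon.

The closest measured change at this place is a 1.1-fold higher number from compound 2 to compound 3 (0.02 log units; within the scatter). The other two steps add no size: a step that the limit leaves unreadable from compound 1 to compound 2 and a step that the limit leaves unreadable from compound 1 to compound 3. Among the compounds with values here, compound 1 is the only measured compound with a carboxy group, so it gives direction only weakly. With compound 2 and compound 3 within the scatter (a 1.1-fold higher number from compound 2 to compound 3 (0.02 log units; within the scatter)), no step beyond the scatter is expected in this assay. The expected step is a 1.1-fold higher number from compound 3 to compound 4 (0.05 log units; within the scatter). For compound 4 the estimated value is 60000 nM, with an expected range of 30000 nM to 120000 nM.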

Compound 4, half-maximal inhibitory concentration: > 50000 nM
Compound 4 gave a limit, no number; the forecaster's own chance of this, stated with the estimate: 45%; the middle value is on the limit's open side.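

Within the data shown here, compound 4 gives > 50000 nM, which is a limit and not a number, so no step from compound 1, compound 2 or compound 3 to compound 4 can be read. The compounds shown leave open whether the carboxy-bearing compound 1 and compound 4 differ at all from compound 2 and compound 3.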